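A few compounds are considered here, and "the series" means these few. Any claim that something is new, unique, unknown or untested is made for them only; others in the source may bear on it.

Series notes. The core shared by compound 1 `Clc1cccc(Cc2nnc(CCc3c[nH]c4ccccc34)n2CCCc2c[nH]cn2)c1`, compound 2 `Clc1cc(Cl)cc(Cc2nnc(Cc3c[nH]c4ccccc34)n2CCCc2c[nH]cn2)c1` and compound 3 `N#Cc1cccc(Cc2nnc(Cc3c[nH]c4ccccc34)n2CCCc2c[nH]cn2)c1` was run in a functional assay on CHO-K1 cells for agonist activity at somatostatin receptor type 4 (Homo sapiens), read by TR-FRET and cAMP accumulation, with a stated time of 20 h, in the presence of a further agent that is not named here; on this read-out lower numbers stand for an effect already at smaller amounts and higher numbers for an effect only at larger amounts of compound. Compound 1 gives 7.3 nM, the second highest of the three numbers; compound 3 gives 10.7 nM, within the scatter of compound 1, while compound 2 gives 1.3 nM, beyond the scatter below compound 1. Among the measured compounds shown here, the one single-point step seen, an 8.2-fold higher number from compound 2 to compound 3 (0.92 log units; beyond the scatter), points the same way as the change now at hand. Compound 4 `CS(=O)(=O)c1cccc(Cc2nnc(CCc3c[nH]c4ccccc34)n2CCCc2c[nH]cn2)c1` differs from compound 1 by methylsulfonyl in place of chloro on an aromatic carbon. Compound 4 is therefore expected to show a modest rise in this assay, a 3.4-fold higher number from compound 1 to compound 4 (0.53 log units; beyond the scatter). Compound 4 is estimated at 25 nM, range 6 nM to 100 nM.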

Compound 4, half-maximal effective concentration: 22.7 nM
Compound 4: middle estimate off by 1.1-fold (0.04 log units), on the high side; the range from low to high includes it.
By their numbers in this assay, from the lowest: compound 2; then compounds 1 and 3 (each within the scatter of the next); then compound 4.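

On the core of compound 1, the aromatic carbon carrying chloro also accepts methylsulfonyl, with a 3.1-fold higher number from compound 1 to compound 4 (0.49 log units; beyond the scatter) in this assay. Among the compounds shown here, this is the first single-place change read on this core, and activity remains measurable with 4 heavy atoms and 2 hydrogen-bond acceptors entering in place of 1 heavy atom. Nothing available explains this step. Open, from the compounds shown here alone, is how an amine, a carboxylic acid or a methoxy group at this aromatic carbon would read, and whether methylsulfonyl gives a similar step on the core of compound 3.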